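The source may hold more compounds than are shown below. What is called first, only, known or untested is meant among the compounds shown, and "the series" means these compounds.

Compound 1 `CCCc1nc(-c2ccccc2)c(CNCCCN2CCN(c3cccc(C(F)(F)F)c3)CC2)o1`: 51.6%
Compound 2 `CCCc1nc(-c2ccccc2)c(CNCCCN2CCN(c3cccc(C)c3C)CC2)o1`: 55.2%

In an assay on HEK293 cells for inhibition of Voltage-dependent T-type calcium channel subunit alpha-1G (Homo sapiens), read by fluorescence, tested at 10 uM (on this read-out higher numbers stand for more inhibition at the one concentration tested (going by the name of the read-out) and lower numbers for less inhibition), compound 2 gives 55.2% and compound 1 gives 51.6%; the two cannot be told apart, since a number 3.6 percentage points higher from compound 1 to compound 2 (within the scatter). Compound 3 `CCCc1nc(-c2ccccc2)c(CNCCCN2CCN(c3ccccc3)CC2)o1` differs from compound 2 by phenyl in place of 2,3-dimethylphenyl on an amine nitrogen in a ring. Within the data shown here, the only step that bears on this exchanges one ring on that same ring nitrogen for another, and it stayed within the scatter, as a number 3.6 percentage points higher from compound 1 to compound 2 (within the scatter) shows. Compound 3 is therefore expected to show no step beyond the scatter, a number 5.2 percentage points lower from compound 2 to compound 3 (within the scatter). The estimate for compound 3 is 50%, between 30% and 70%.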

Compound 3, a percentage reported as inhibition, at one concentration (the size of the read-out at that concentration, not a potency): 43.7%
Compound 3: middle estimate off by 6.3 percentage points, on the high side; the measured number falls inside the stated range.
By their numbers in this assay, from the lowest: compounds 3, 1 and 2 (each within the scatter of the next, the first and the last beyond it).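

Among these compounds, on the amine nitrogen in the ring, the aryl group can now be seen to matter in this assay: phenyl in place of 2,3-dimethylphenyl gives a number 11.5 percentage points lower from compound 2 to compound 3 (beyond the scatter) and is the first step here beyond the scatter, though a modest one. Phenyl and 3-(trifluoromethyl)phenyl remain hard to separate, with a number 7.9 percentage points lower from compound 1 to compound 3 (within the scatter) on swapping trifluoromethyl for hydrogen. No supporting measurement is available to explain these differences. From the compounds shown here alone, whether a single methyl group on the phenyl ring would match the two stays open. So does the effect of a chlorine atom or a methoxy group there.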